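The source may report more compounds than this note shows. Statements on the series, on what has been measured and on what is new or still open speak of the compounds shown alone.

Measured compounds, with their values in a functional assay on MCF7 cells (Homo sapiens) for inhibition, read by MTT assay, with a stated time of 48 h; a lower number here means a stronger inhibitor, a higher number a weaker inhibitor:
- compound 1, `COc1ccc(C(=O)/C=C/c2cc(-c3cc(OC)c(OC)c(OC)c3)n[nH]2)cc1`: 810 nM
- compound 2, `COc1cc(-c2cc(/C=C/C(=O)c3ccc(F)c(F)c3)[nH]n2)cc(OC)c1OC`: 2500 nM
- compound 3, `COc1ccc(C(=O)/C=C/c2cc(-c3cc(OC)c(OC)c(OC)c3)n[nH]2)cc1F`: 3000 nM

Compound 3 has the highest number of the three in this assay; it sits close to compound 2, while the wider gap is a 3.7-fold higher number from compound 1 to compound 3 (0.57 log units; beyond the scatter). Compound 4, `COc1cc(-c2cc(/C=C/C(=O)c3ccc(Cl)cc3)[nH]n2)cc(OC)c1OC`, is not yet measured. It differs from compound 3 in one place: 4-chlorophenyl in place of 3-fluoro-4-methoxyphenyl on a carbonyl carbon.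

Among the measured compounds shown here, two measured steps bear on this. Replacing the 4-methoxyphenyl of compound 1 with a 3,4-difluorophenyl gave a 3.1-fold higher number from compound 1 to compound 2 (0.49 log units; beyond the scatter), and adding a fluoro to that same ring gave a 3.7-fold higher number from compound 1 to compound 3 (0.57 log units; beyond the scatter). Between compound 2 and compound 3, which both carry a halogen on that ring, the step was a 1.2-fold higher number from compound 2 to compound 3 (0.08 log units; within the scatter). Compound 4 keeps a halogen on the ring and gives up the methoxy, so it is expected to behave like compound 2 and compound 3 rather than compound 1, with a step of a 1.2-fold lower number from compound 3 to compound 4 (0.08 log units; within the scatter) expected from compound 3 to compound 4, not beyond the scatter. Compound 4 is therefore estimated at 2500 nM in this assay, within a range of 1000 nM to 7000 nM.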

Compound 4, half-maximal inhibitory concentration: 11600 nM
The estimate for compound 4 lay 4.6-fold (0.67 log units) below the measured number; measured number outside the range, above it.
By their numbers in this assay, from the lowest: compound 1; then compounds 2 and 3 (each within the scatter of the next); then compound 4.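

In this assay, a halogen on the ring at the carbonyl carbon does not by itself set the level: compounds 2 and 3 lay within the scatter of each other, yet 4-chlorophenyl gave a 3.9-fold higher number from compound 3 to compound 4 (0.59 log units; beyond the scatter) and a 4.6-fold higher number from compound 2 to compound 4 (0.67 log units; beyond the scatter). Chloro in place of methoxy gave a 14-fold higher number from compound 1 to compound 4 (1.16 log units; beyond the scatter), a large step, so this position responds more strongly to the change than the earlier, modest steps away from compound 1 had shown. No measurement available here accounts for these steps.

The compounds shown leave open whether the higher number of compound 4 belongs to the chloro itself or to the loss of the other groups on that ring. Going by these compounds, how a lone fluoro, an amine or a carboxylic acid at the same place would read also remains open.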